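Replacing cyano with methyl on a selenium

A few compounds are considered here, and "the series" means these few. Any claim that something is new, unique, unknown or untested is made for them only; others in the source may bear on it.

In a functional assay on HeLa cells (Homo sapiens) for antiproliferative activity, read by MTT assay, with a stated time of 48 h (on this read-out lower numbers stand for stronger inhibition and higher numbers for weaker inhibition), compound 1 (`COc1ccc(N(C)c2cc(C)nc(C)n2)cc1`) gives 322 nM as its half-maximal inhibitory concentration, and compound 2 (`Cc1cc(N(C)c2ccc([Se]C#N)cc2)nc(C)n1`) gives 252 nM on the same read-out. These two numbers lie within the scatter of each other, so compound 2 stands level with compound 1 and the pair cannot be ranked.

Compound 3 (`C[Se]c1ccc(N(C)c2cc(C)nc(C)n2)cc1`) differs from compound 2 in one place, with methyl in place of cyano on a selenium. Going by the values given here, only one measured step bears on this change, namely a 1.3-fold lower number from compound 1 to compound 2 (0.11 log units; within the scatter) and it stays within the scatter. Among the compounds with values here, that step concerns a different exchange, and no measured pair isolates cyano against methyl on a selenium, so the guidance is thin. Within the data shown here, with compound 2 as the starting point and that single small step as the only precedent, no step beyond the scatter is expected in this assay and neither direction is favoured. The estimate therefore amounts to a 1.0-fold lower number from compound 2 to compound 3 (0.00 log units; within the scatter) and nothing larger is expected. For compound 3 the estimated value is 250 nM with an expected range from 90 nM to 700 nM across repeated measurements.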

Compound 3, half-maximal inhibitory concentration: 138 nM
Beside the measured number, compound 3's estimate is 1.8-fold (0.26 log units) above it; low and high end bracket the measured number.
By their numbers in this assay, from the lowest: compounds 3, 2 and 1 (each within the scatter of the next, the first and the last beyond it).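

In this assay, the exchange on the selenium gives a 1.8-fold lower number from compound 2 to compound 3 (0.26 log units; within the scatter), so the methyl and cyano groups cannot be ranked at this position, and the selenium carries either one without a step that can be told from the scatter. The sharper contrast lies with the methoxy group of compound 1: a 2.3-fold lower number from compound 1 to compound 3 (0.37 log units; beyond the scatter) is the first step in this set to pass beyond the scatter, though only modestly, whereas a 1.3-fold lower number from compound 1 to compound 2 (0.11 log units; within the scatter) does not, so among these three compounds only the methyl on a selenium separates from the methoxy compound. Nothing shown explains either step or says what the exchange of oxygen for selenium changes in these cells.

From the compounds shown here alone, what stays open is whether a longer chain such as ethyl on the selenium, or an amine or a carboxylic acid carried on that chain, would keep a number like that of compound 3. Also open, going by these compounds, is whether a sulfur atom in place of the selenium would hold the modest gain over compound 1, or whether that gain belongs to selenium alone.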